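The source may hold more compounds than are shown below. What is called first, only, known or untested is meant among the compounds shown, and "the series" means these compounds.

Measured so far:
compound 1, `C/C(=N\OCCSc1nnnn1C)c1ccc(Sc2cc(F)cc(C3CCOCC3)c2)cc1`: 120 nM
compound 2, `COC1(c2csc(Sc3ccc4c(c3)OCC/C4=N\OCC#N)c2)CCOCC1`: 60 nM
compound 3, `CO[C@]1(c2cnc(Sc3ccc(/C(C)=N/O)cc3)s2)CCO[C@@H](C)C1`: 40 nM

Three compounds have been run in a functional assay (blood) for inhibition, with Homo sapiens as the target; a lower number here means a stronger inhibitor, a higher number a weaker inhibitor. Compound 1 stands at the highest of the three numbers. Its nearest neighbour is compound 2, whose half-maximal inhibitory concentration lies within the usual scatter of that of compound 1, so the two cannot be told apart. Compound 3 gives a lower number than compound 1, and that gap lies beyond the scatter.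

The unmeasured compound 4, `CCOC(=O)CO/N=C(\C)c1ccc(Sc2cc(F)cc(C3CCOCC3)c2)cc1`, keeps the core of compound 1 and differs from it in one place: ethoxycarbonyl in place of ((1-methyl-1H-tetrazol-5-yl)sulfanyl)methyl on a saturated chain carbon bound to an oxygen. Among the measured compounds shown here, no pair of measured compounds shows this exact change, so there is no measured step to lean on. Because compound 1 gives 120 nM in this assay and the change touches only the tail bound to the oxygen, compound 4 is expected to land close to compound 1, with a step of a 1.3-fold higher number from compound 1 to compound 4 (0.10 log units; within the scatter) that is not expected to exceed the scatter. Compound 4 is therefore estimated at 150 nM, in a range from 50 nM to 450 nM.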

Compound 4, half-maximal inhibitory concentration: 610 nM
Estimate against measurement, compound 4: 4.1-fold (0.61 log units) below; the measured number lies above the stated range.
By their numbers in this assay, from the lowest: compounds 3, 2 and 1 (each within the scatter of the next, the first and the last beyond it); then compound 4.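

In this assay, the tail bound to the oxygen turns out not to be a silent part of the core of compound 1: putting ethoxycarbonyl in place of ((1-methyl-1H-tetrazol-5-yl)sulfanyl)methyl on a saturated chain carbon bound to an oxygen gives a 5.1-fold higher number from compound 1 to compound 4 (0.71 log units; beyond the scatter) and so a weaker inhibitor. The earlier compounds shown here differ from one another in more than one place, so they could not isolate this position, and this step now shows that the choice of group there can move the number beyond the scatter. Nothing at hand bears on why the number rises.

Going by these compounds, it remains open whether the ring, the sulfur or the ester carries the step. The compounds shown also leave open how a carboxylic acid, a primary amide or a plain longer alkyl chain would read at this same carbon.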